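The source may hold more compounds than are shown below. What is called first, only, known or untested is meant among the compounds shown, and "the series" means these compounds.

Compound 3 `Clc1ccc(Cc2nn3c(Br)c(-c4ccc(Br)cc4)nc3s2)cc1` carries a 4-bromophenyl group on the shared core. In a functional assay on L1210 cells (Mus musculus) for cytotoxicity, with a stated time of 48 h (a lower number here means a stronger inhibitor, a higher number a weaker inhibitor), compound 3 gives > 250000 nM, and this is a limit of the assay rather than a measured number. Compound 2 `Fc1ccc(-c2nc3sc(Cc4ccc(Cl)cc4)nn3c2Br)cc1` likewise gives only a limit in this assay, > 250000 nM. Compound 1 `Cc1ccc(-c2cn3nc(Cc4ccc(Cl)cc4)sc3n2)cc1` also stands at a limit in this assay, with > 250000 nM. Among the measured compounds shown here, the single step between measured compounds, a step that the two limits leave unreadable from compound 2 to compound 3, cannot be read because both of its ends sit at the limit of > 250000 nM in this assay, at which 3 of the 3 values shown sit. So far no compound has given a number, and compound 3 stands where every other measured compound stands.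

Compound 4 `Cc1ccc(-c2nc3sc(Cc4ccc(Cl)cc4)nn3c2Br)cc1` has not yet been measured. It differs from compound 3 by methyl in place of bromo on an aromatic carbon. For the measured compounds named here, no measured step shows what this exchange does, as every value so far is a limit. Compound 1 bears the same 4-methylphenyl group and sits at a limit in this assay. Compound 4 is therefore expected to remain at the limit as well, and the step from compound 3 to compound 4 is estimated as a step that the limit leaves unreadable from compound 3 to compound 4. The expected value for compound 4 is 300000 nM, within a range from 100000 nM to 1000000 nM.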

Compound 4, half-maximal inhibitory concentration: > 250000 nM
Compound 4 ended at the assay's limit (the forecaster's own chance of this, stated with the estimate: 90%); the middle value is on the limit's open side.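

Compound 4 ends at a limit of the assay, as do compound 1, compound 2 and compound 3, so none of the steps linking them can be read: the limit of > 250000 nM in this assay, at which 4 of the 4 values shown sit. The compounds shown leave open what exchanging bromo, fluoro and methyl does in this assay.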